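A Sulfur-Linked Aryl Swap at Low Growth Inhibition

This account rests on a few compounds, and the source may have more. Where it says the series, first, only, none or still open, it means among the compounds named here.

compound 1 `Nc1ccccc1NC(=O)/C=C/c1ccc(CSc2ccc(C(F)(F)F)cn2)cc1` gives 12.1%
compound 2 `Nc1ccccc1NC(=O)c1ccc(CSc2ccc(F)cc2)cc1` gives 6.58%

In a functional assay on SMMC-7721 cells (Homo sapiens) for inhibition, read by CCK-8 assay, with a stated time of 72 h, tested at 2 uM (a higher number here means more inhibition of growth at the concentration tested, a lower number less inhibition of growth), compound 1 and compound 2 lie within the usual scatter of each other, so compound 1 holds no clear rank, and both values are low. Compound 3 `CC(C)(C)c1ccc(SCc2ccc(/C=C/C(=O)Nc3ccccc3N)cc2)cc1` keeps the core of compound 1 but carries 4-(tert-butyl)phenyl in place of 5-(trifluoromethyl)pyridin-2-yl on a sulfur. Going by the values given here, no measured pair differing in one place is available, so the data give no direct size for such a change. A small upward step that stays within the scatter is expected. The estimated step is a number 4.9 percentage points higher from compound 1 to compound 3 (within the scatter) and it would leave the value low. This expectation rests on compound 1 (12.1%) and compound 2 (6.58%). In this assay compound 3 is estimated at 17% (expected range 5% to 38%).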

Compound 3, percent growth inhibition at one concentration: 18.3%
Compound 3: the middle estimate sits 1.3 percentage points below what was measured, within the range that was stated.
By their numbers in this assay, from the lowest: compounds 2, 1 and 3 (each within the scatter of the next, the first and the last beyond it).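

In this assay, going by these compounds alone, the swap of 5-(trifluoromethyl)pyridin-2-yl for 4-(tert-butyl)phenyl on a sulfur gives the first step that can be read at a single place, and it is a number 6.2 percentage points higher from compound 1 to compound 3 (within the scatter). The position, on a sulfur whose other neighbours are a saturated chain carbon, therefore takes an aromatic ring of carbon only in place of one with a hetero atom, at the same count of heavy atoms, with no difference that stands clear of the scatter. No evidence at hand accounts for the size of this step.

On these data alone, whether any group on this sulfur can give a step beyond the scatter remains open, for instance a phenyl ring bearing an amine or a carboxylic acid. Compound 2 differs from compound 1 in more than one place, so the contribution of the rest of the core cannot be separated from that of the aryl group.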